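Adding a Chloro Group to Compound 2's Benzoxazole

A few compounds are considered here, and "the series" means these few. Any claim that something is new, unique, unknown or untested is made for them only; others in the source may bear on it.

Measured compounds:
- compound 1, `Cn1c(-c2ccc(NC(=O)CCl)cc2)nc(-c2ccccc2)c1-c1ccccc1`: 23.7%
- compound 2, `Cn1c(-c2ccc(NC(=O)CSc3nc4ccccc4o3)cc2)nc(-c2ccccc2)c1-c1ccccc1`: 56.2%

Of the compounds shown here, two with a shared core have been tested in a functional assay on HT-29 cells (Homo sapiens) for cytotoxicity, read by MTT assay, with a stated time of 24 h, tested at 16 ug/mL; a lower number here means a weaker effect, a higher number a stronger effect of the compound at the concentration tested. Compound 1 gives 23.7%, and compound 2 gives 56.2%, the higher of the two numbers. Within the data shown here, the one measured step, a number 32.5 percentage points higher from compound 1 to compound 2 (beyond the scatter), puts (1,3-benzoxazol-2-yl)sulfanyl in place of chloro on a saturated chain carbon bound to a carbonyl carbon.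

Compound 3 `Cn1c(-c2ccc(NC(=O)CSc3nc4cc(Cl)ccc4o3)cc2)nc(-c2ccccc2)c1-c1ccccc1` has not yet been measured. It differs from compound 2 by chloro in place of hydrogen on an aromatic carbon, on an aromatic carbon of a six-membered aromatic ring of carbon only, part of a fused system of two rings. Among the measured compounds shown here, no measured step touches this position, so the single step between compound 1 and compound 2 gives no guidance on its size or direction. Compound 3 is therefore expected to give about 56%, within 40% to 72%, a step of a number 0.2 percentage points lower from compound 2 to compound 3 (within the scatter) expected to stay within the scatter.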

Compound 3, a percentage reported as activity, at one concentration (the size of the read-out at that concentration, not a potency): 42.5%
Compound 3: middle estimate off by 13.5 percentage points, on the high side; low and high end bracket the measured number.
By their numbers in this assay, from the lowest: compound 1; then compound 3; then compound 2.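

In this assay, the change to 5-chloro-1,3-benzoxazol-2-yl gives a number 13.7 percentage points lower from compound 2 to compound 3 (beyond the scatter) and so shows that this aromatic carbon is not a silent place for a substituent: a single chlorine there lowers the read-out. The (5-chloro-1,3-benzoxazol-2-yl)sulfanyl group still gives a number 18.8 percentage points higher from compound 1 to compound 3 (beyond the scatter) when it replaces the chloro on the chain, so part of the gain from compound 1 survives the added chlorine. Nothing at hand accounts for the drop at this position.

On these data alone, it remains open whether the drop is particular to chloro or would also follow from a fluoro, a methoxy or an amine on the same carbon. As far as these compounds go, it is also open whether a chloro on another carbon of the six-membered ring would lower the read-out in the same way.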